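This account rests on a few compounds, and the source may have more. Where it says the series, first, only, none or still open, it means among the compounds named here.

Compound 1 `O=C(Nc1ccc([N+](=O)[O-])cc1Cl)c1ccc(Cl)cc1O` and compound 2 `COc1ccc(O)c(C(=O)Nc2ccc([N+](=O)[O-])cc2Cl)c1` share a core with compound 3 `O=C(Nc1ccc([N+](=O)[O-])cc1Cl)c1cc([N+](=O)[O-])ccc1O`, which has yet to be tested. In an ADME assay for permeability, using PAMPA (on this read-out higher numbers stand for higher permeability and lower numbers for lower permeability), compound 1 has no numerical result, and its entry reads "not determined" (no result reported) in the data. Among the compounds with values here, compound 2 gives 67.1 10^-6 cm/s and this is the only number available, so it cannot yet be ranked against any other compound.

Compound 3 differs from compound 2 in one place, counted as nitro in place of methoxy on an aromatic carbon in the structures. It carries nitro in place of methoxy on an aromatic carbon, para to a hydroxy group. Within the data shown here, no measured pair shows what this swap does in this assay, so the forecast here is a judgement and not a trend read from data. The step of a 4.5-fold lower number from compound 2 to compound 3 (0.65 log units; beyond the scatter) is expected to be a fall larger than the usual scatter of repeat measurements. For compound 3 the estimated value is 15 10^-6 cm/s with an expected range from 3 10^-6 cm/s to 55 10^-6 cm/s and this range is kept wide, as a single number offers little to anchor it.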

Compound 3, apparent permeability: 30.3 10^-6 cm/s
Compound 3: middle estimate off by 2.0-fold (0.31 log units), on the low side; measured number inside the range.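

In this assay, placing nitro in place of methoxy on this aromatic carbon, para to a hydroxy group, gives a 2.2-fold lower number from compound 2 to compound 3 (0.35 log units; beyond the scatter). Within the data shown here, this is the first measured step, and it shows that the read-out responds to a change of group at this position, although the step is only modest in size and compound 3 still gives a clear number of 30.3 10^-6 cm/s. Neither group carries a net charge or a hydrogen-bond donor, so the step comes with a change in heavy atoms and hydrogen-bond acceptors alone, and nothing in the data explains why the number falls.

One step from one pair cannot show whether the fall is particular to nitro or would appear with other replacements for methoxy, and compound 1, at "not determined" (no result reported), adds no second comparison. On these data alone, how an amine, a carboxylic acid or a longer alkoxy chain at this same position would compare with methoxy and nitro remains open, as does whether the step would keep its size on a different core.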